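Compound 3: triazolylmethyl in place of thienylmethyl

A few compounds are considered here, and "the series" means these few. Any claim that something is new, unique, unknown or untested is made for them only; others in the source may bear on it.

Measured in a functional assay on SNB-19 cells (Homo sapiens) for inhibition, read by MTT assay, with a stated time of 7 days; on this read-out higher numbers stand for weaker inhibition of growth and lower numbers for stronger inhibition of growth:
- compound 1 `C#CCn1nnc2c(C(N)=O)ncn2c1=O`: 35600 nM
- compound 2 `NC(=O)c1ncn2c(=O)n(Cc3cccs3)nnc12`: > 50000 nM (a limit, not a number)

Compound 2 gives no number, only the limit > 50000 nM. That entry is the limit of > 50000 nM in this assay, at which 1 of the 2 values shown sits.

Compound 3 `NC(=O)c1ncn2c(=O)n(Cc3c[nH]nn3)nnc12` differs from compound 2 in one place, with 1H-1,2,3-triazol-4-yl in place of thiophen-2-yl on a saturated chain carbon bound to an aromatic nitrogen.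

Among the compounds with values here, one measured step bears on this change, as it alters the group at the same place: thiophen-2-yl in place of ethynyl gave an at least 1.4-fold higher number from compound 1 to compound 2 (0.14 log units; that floor lies within the scatter). Within the data shown here, no measured step covers the triazolyl group itself, so the expectation rests on this single step, whose true size is unknown.

Compound 3 is therefore expected to stay at the weak end of this assay, and it may also return only a limit. The expected step is an at least 1.1-fold lower number from compound 2 to compound 3 (0.04 log units; that floor lies within the scatter), which means no change beyond the scatter is expected. For compound 3 the estimate is 45000 nM, with an expected range of 25000 nM to 80000 nM.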

Compound 3, concentration for 50% growth inhibition: > 50000 nM
Compound 3: no number, only a limit; the forecaster's own chance of this, stated with the estimate: 55%; at least 1.1-fold (0.04 log units) between middle value and limit.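

In this assay compound 3 gives only a limit, as compound 2 does, so a change from thiophen-2-yl to 1H-1,2,3-triazol-4-yl on a saturated chain carbon bound to an aromatic nitrogen, with a hydrogen-bond donor entering and more hetero atoms in the ring, still yields no number. The step between these two compounds cannot be read, and the only readable comparison at this position is an at least 1.4-fold higher number from compound 1 to compound 3 (0.14 log units; that floor lies within the scatter), so neither ring in place of ethynyl is shown to shift the read-out beyond the scatter. The position now holds two different five-membered aromatic rings whose entries both end at the same ceiling, and this leaves them without any ranking: the limit of > 50000 nM in this assay, at which 2 of the 3 values shown sit.

Within the data shown here, still open is whether compound 2 and compound 3 truly differ from each other or from compound 1, whose value of 35600 nM is the only number in the set. Also open, as far as these compounds go, is whether an amine, a carboxylic acid or a longer chain at the same place would give a value that can be read in this assay.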